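A longer chain on the chlorinated compound

The source may report more compounds than this note shows. Statements on the series, on what has been measured and on what is new or still open speak of the compounds shown alone.

Compound 1 (`CS(=O)(=O)c1ccc2c(c1)c(C1CCN(CCN3CCNC3=O)CC1)cn2-c1ccc(F)cc1`) with (54 umol/kg)
Compound 2 (`Cc1ccc2c(c1)c(C1CCN(CCN3CCNC3=O)CC1)cn2-c1ccc(F)cc1`) with (0.0083 umol/kg)
Compound 3 (`O=C1NCCN1CCCCCN1CCC(c2cn(-c3ccc(F)cc3)c3ccc(Cl)cc23)CC1`) with (1.5 umol/kg)

All three values come from a functional assay on the whole organism for inhibition, with Rattus norvegicus as the target (a lower number here means that less compound is needed, a higher number that more compound is needed for the effect), and they spread widely. Compound 3 (1.5 umol/kg) stands in the middle on this scale, with compound 1 (54 umol/kg) at the top end and compound 2 (0.0083 umol/kg) at the bottom end.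

Compound 4 (`O=C1NCCN1CCCCCCN1CCC(c2cn(-c3ccc(F)cc3)c3ccc(Cl)cc23)CC1`) departs from compound 3 in one place ((2-oxoimidazolidin-1-yl)methyl in place of 2-oxoimidazolidin-1-yl on a saturated chain carbon, five bonds along the chain from an amine nitrogen in a ring) on a saturated chain carbon, five bonds along the chain from an amine nitrogen in a ring. The same difference reads 3-(2-oxoimidazolidin-1-yl)propyl to 4-(2-oxoimidazolidin-1-yl)butyl.

For the measured compounds named here, the only measured single-place step (a 6500-fold lower number from compound 1 to compound 2 (3.81 log units; beyond the scatter)) is large, but it is methyl in place of methylsulfonyl on an aromatic carbon, so it does not speak to the chain. Going by the values given here, no measured step changes the chain alone, and compound 2 and compound 3 differ in more than one place. With nothing closer to go on, no step beyond the scatter is expected in this assay for this change, though the uncertainty is wide.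

The estimated step is a 1.3-fold higher number from compound 3 to compound 4 (0.12 log units; within the scatter) and no more than that. For compound 4 the expected value is 2 umol/kg with an estimated range from 0.3 umol/kg to 12 umol/kg in this test.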

Compound 4, dose for half-maximal effect: > 2.2 umol/kg
Compound 4: no number, only a limit; the forecaster's own chance of this, stated with the estimate: 3%; middle value at least 1.1-fold (0.04 log units) away from the limit.
By their numbers in this assay, from the lowest: compound 2; then compound 3; then compound 1.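

In this assay, compound 4 carries only a limit, > 2.2 umol/kg, and not a number. Going from 3-(2-oxoimidazolidin-1-yl)propyl to 4-(2-oxoimidazolidin-1-yl)butyl is the only change in the chain among the compounds shown, and it gives an at least 1.4-fold higher number from compound 3 to compound 4 (0.16 log units; that floor lies within the scatter), so the true gap could be small or far larger. The earlier compounds said nothing about this position, and the result now rules out that this longer chain lowers the number relative to compound 3, though the size of any rise stays unknown: the limit of > 2.2 umol/kg in this assay, at which 1 of the 4 values shown sits.

The compounds shown leave open how a shorter chain, the 2-(2-oxoimidazolidin-1-yl)ethyl carried by compound 1 and compound 2, would read on the chlorinated core of compound 3, which would show whether chain length matters on that core in either direction. They also leave open whether a chain longer still, or an amine in place of the 2-oxoimidazolidin-1-yl group at the chain end, would stay close to compound 3 in this assay or move well away from it.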